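The source may hold more compounds than are shown below. What is called first, only, known or untested is meant among the compounds shown, and "the series" means these compounds.

Among the measured compounds shown here, compound 3, `Cc1cc(C(=O)O)nn1Cc1cc(Br)ccc1OCc1ccc(Cl)cc1Cl`, is the only member of this set for which a functional assay on CHO-K1 cells for antagonist activity at prostaglandin E2 receptor EP1 subtype (Homo sapiens), read by FLIPR (on this read-out lower numbers stand for stronger inhibition and higher numbers for weaker inhibition), gives a number: compound 3 gives 0.49 nM. The two other compounds reach only a limit of the assay. Compound 1, `O=C(O)c1nn(Cc2cc(Br)ccc2OCc2ccccc2)cc1Br`, sits at a limit in this assay, at < 2000 nM. Compound 2, `O=C(O)c1ccnn1Cc1cc(Br)ccc1OCc1ccccc1`, likewise sits at a limit in this assay, with < 2000 nM. Two of the three values shown therefore rest at the limit of < 2000 nM in this assay, at which 2 of the 3 values shown sit, so compound 3 cannot be placed against either of them by a step of known size.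

Compound 4, `Cc1cc(C(=O)O)nn1Cc1cc(Br)ccc1OCc1ccccc1Cl`, differs from compound 3 by hydrogen in place of chloro on an aromatic carbon, the 2,4-dichlorobenzyl becoming a 2-chlorobenzyl. For the measured compounds named here, no step between measured compounds describes this change, so its size is open. Some loss of inhibition is expected from compound 3 to compound 4, of a 4.1-fold higher number from compound 3 to compound 4 (0.61 log units; beyond the scatter), likely somewhat beyond the scatter but not large. Compound 4 is estimated at 2 nM, within a range from 0.4 nM to 10 nM.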

Compound 4, inhibition constant: 28.8 nM
Estimate against measurement, compound 4: 14-fold (1.16 log units) below; the measured number lies above the stated range.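

In this assay, the chloro para to a large group and meta to a chloro group proves to matter a great deal: replacing it with hydrogen, the 2,4-dichlorobenzyl becoming a 2-chlorobenzyl, gives a 59-fold higher number from compound 3 to compound 4 (1.77 log units; beyond the scatter). Among the compounds shown here, this is the first step of known size in the set, and it shows that losing 1 heavy atom, with no ring, hydrogen-bond donor, hydrogen-bond acceptor or net charge involved, can move the number well beyond the scatter. Nothing among the data shown explains why this step is so large.

The compounds shown leave open whether chloro itself is needed at this place, or whether a fluoro, a methyl or a methoxy would serve as well. Also open, from the compounds shown here alone, is how much the remaining chloro of the 2-chlorobenzyl contributes.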